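Hydroxy to Methoxy on the Core: Expected Cytotoxicity

This account rests on a few compounds, and the source may have more. Where it says the series, first, only, none or still open, it means among the compounds named here.

compound 1 `COc1ccc2c(=O)c(/C=C/C(=O)Nc3cccc(C)c3)coc2c1` — 554000 nM
compound 2 `COc1cccc(NC(=O)/C=C/c2coc3cc(OC)ccc3c2=O)c1` — 1130000 nM
compound 3 `Cc1ccccc1NC(=O)/C=C/c1coc2cc(O)ccc2c1=O` — 374000 nM

In an ADME assay on HepG2 2.2.15 cells (Homo sapiens) for cytotoxicity, read by MTT assay, with stated times of 48 h and 9 days (on this read-out lower numbers stand for higher toxicity in this test and higher numbers for lower toxicity in this test), compound 3 gives the lowest of the three numbers; compound 1 lies within the scatter of it, compound 2 beyond. Compound 4 `COc1ccc2c(=O)c(/C=C/C(=O)Nc3ccccc3C)coc2c1` differs from compound 3 by methyl in place of hydrogen on an oxygen on an aromatic ring. Within the data shown here, the only measured step, a 2.0-fold higher number from compound 1 to compound 2 (0.31 log units; beyond the scatter), changes a group on an aromatic carbon rather than on a ring oxygen, so it bears only loosely here. Compound 1 already carries the methoxy on the core and gives 554000 nM, within the scatter of compound 3. The step from compound 3 to compound 4 is therefore expected to be small, a 1.3-fold higher number from compound 3 to compound 4 (0.13 log units; within the scatter), if anything toward higher numbers. Compound 4 is estimated at 500000 nM, ranging from 250000 nM to 1000000 nM.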

Compound 4, half-maximal cytotoxic concentration: 59700 nM
Estimate against measurement, compound 4: 8.4-fold (0.92 log units) above; the whole stated range lies above it.
By their numbers in this assay, from the lowest: compound 4; then compounds 3 and 1 (each within the scatter of the next); then compound 2.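

In this assay the change from hydroxy to methoxy on the core is a real step when 2-methylphenyl sits on the amide-type nitrogen (a 6.3-fold lower number from compound 3 to compound 4 (0.80 log units; beyond the scatter)). With the methoxy kept, the group on that nitrogen also matters: 2-methylphenyl in place of 3-methylphenyl gives one step (a 9.3-fold lower number from compound 1 to compound 4 (0.97 log units; beyond the scatter)), and 2-methylphenyl in place of 3-methoxyphenyl gives a larger one (a 19-fold lower number from compound 2 to compound 4 (1.28 log units; beyond the scatter)). No measurement here accounts for these steps.

Going by these compounds, it remains open whether hydroxy to methoxy gives a step of this size with other groups on the amide-type nitrogen. On these data alone, what an ethyl or a longer chain on that oxygen would give also remains open.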